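The source may report more compounds than this note shows. Statements on the series, on what has been measured and on what is new or still open speak of the compounds shown alone.

Going by the values given here, compound 1 `COC1=CC(c2cc3ccccc3[nH]2)=N/C1=C\c1ccc(-c2cc3ccccc3[nH]2)[nH]1` is the only compound with a number in a functional assay on PLC5 cells (Homo sapiens) for cytotoxicity, read by MTT assay; on this read-out lower numbers stand for stronger inhibition and higher numbers for weaker inhibition: compound 1 gives 15900 nM. Compound 2 `COc1cc(-c2cc3ccccc3n2C(=O)OC(C)(C)C)[nH]c1/C=C1/SC(=O)NC1=O` returns only a limit in this assay, > 40000 nM. Among the compounds with values here, compound 1 therefore holds the sole numerical value, with the limit of > 40000 nM in this assay, at which 1 of the 2 values shown sits, as the other entry. Compound 3 `COC1=CC(c2cc3ccccc3[nH]2)=N/C1=C\c1ccc[nH]1` differs from compound 1 by hydrogen in place of 1H-indol-2-yl on an aromatic carbon. Within the data shown here, no measured pair spans such a change; the step of a 2.2-fold higher number from compound 1 to compound 3 (0.34 log units; beyond the scatter) is expected to lie beyond the scatter, toward weaker inhibition. Compound 3 is estimated at 35000 nM, within 12000 nM to 100000 nM, with a real chance that only a limit is reported.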

Compound 3, half-maximal inhibitory concentration: 13200 nM
Compound 3: middle estimate off by 2.7-fold (0.42 log units), on the high side; low and high end bracket the measured number.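

In this assay, hydrogen in place of 1H-indol-2-yl on this aromatic carbon gives a 1.2-fold lower number from compound 1 to compound 3 (0.08 log units; within the scatter). The number held by compound 1 therefore does not rest on this group, and this place in the series tolerates the loss of both its rings. Nothing in the data shown accounts for this result.

From the compounds shown here alone, whether an amine or a carboxylic acid at this place would shift the number remains open. Also open, going by these compounds, is what the 1H-indol-2-yl still carried by compound 3 on the other side of the core contributes.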